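A few compounds are considered here, and "the series" means these few. Any claim that something is new, unique, unknown or untested is made for them only; others in the source may bear on it.

Compound 2 `Cc1ccccc1Nc1nc(C)c(C(=O)/C=C/c2ccc(Cl)cc2)s1` and compound 1 `Cc1nc(Nc2ccc(Cl)cc2)sc1C(=O)/C=C/c1ccccc1` share one core, differing in the groups at its two ends. In a functional assay on BGC-823 cells (Homo sapiens) for cytotoxicity, read by MTT assay (a lower number here means a stronger inhibitor, a higher number a weaker inhibitor), compound 2 gives > 25000 nM, which is a limit of the assay and not a number. Compound 1 likewise gives only a limit there, > 25000 nM. Both values therefore sit at the limit of > 25000 nM in this assay, at which 2 of the 2 values shown sit. Compound 3 `Cc1ccccc1Nc1nc(C)c(C(=O)/C=C/c2ccccc2)s1` differs from compound 2 by hydrogen in place of chloro on an aromatic carbon. Going by the values given here, no measured step exists between any two compounds, so no direction is known. The expected step is a step that the limit leaves unreadable from compound 2 to compound 3, nothing beyond the scatter. Compound 3 is estimated at 40000 nM, ranging from 20000 nM to 100000 nM.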

Compound 3, half-maximal inhibitory concentration: > 25000 nM
Compound 3: only a limit was reported; the forecaster's own chance of this, stated with the estimate: 80%; the middle value is on the limit's open side.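

As far as these compounds go, compound 3 cannot be compared with compound 1 or compound 2, because each result is only a limit of the assay, not a number: the limit of > 25000 nM in this assay, at which 3 of the 3 values shown sit. Whether swapping chloro for hydrogen, or changing the aromatic group on the nitrogen, alters activity in this assay stays open.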